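The source may hold more compounds than are shown below. What is called first, only, known or untested is meant among the compounds shown, and "the series" means these compounds.

Measured in a functional assay on A549 cells (Homo sapiens) for antiproliferative activity, read by MTT assay, with a stated time of 72 h; on this read-out higher numbers stand for weaker inhibition and lower numbers for stronger inhibition:
- compound 1 `COc1cc2c(Nc3ccc(C#N)cc3)ncnc2cc1OCCCN1CCCC1`: 21800 nM
- compound 2 `COc1cc2c(Nc3ccc(C#N)cc3)ncnc2cc1OCCCN1CCCCC1CCO`: > 100000 nM (a limit of the assay, not a number)
- compound 3 `COc1cc2c(Nc3ccc(C#N)cc3)ncnc2cc1OCCCN1CCN(C)CC1`: 48800 nM

Of the two true numbers, compound 3 has the higher, and so the weaker inhibition, at 48800 nM. The closest comparison is a 2.2-fold higher number from compound 1 to compound 3 (0.35 log units; beyond the scatter).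

Compound 4 `CCN1CCN(CCCOc2cc3ncnc(Nc4ccc(C#N)cc4)c3cc2OC)CC1` differs from compound 3 by methyl in place of hydrogen on a saturated chain carbon bound to an amine nitrogen in a ring, which turns 4-methylpiperazin-1-yl into 4-ethylpiperazin-1-yl. Within the data shown here, no measured step isolates this change. The nearest evidence comes from swapping the whole amine, namely a 2.2-fold higher number from compound 1 to compound 3 (0.35 log units; beyond the scatter) and an at least 4.5-fold higher number from compound 1 to compound 2 (0.66 log units; beyond the scatter), and the reverse swap, an at least 2.0-fold lower number from compound 2 to compound 3 (0.31 log units; beyond the scatter). These exchanges are far larger than the change here, and the modest size of the step to compound 3 sets an upper guide. In this assay, therefore, no step beyond the scatter is expected, with a slight drift towards weaker inhibition at most.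

The estimated step is a 1.0-fold higher number from compound 3 to compound 4 (0.01 log units; within the scatter). For compound 4 the expected value is 50000 nM, within an estimated range of 22000 nM to 100000 nM.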

Compound 4, half-maximal inhibitory concentration: 16000 nM
Compound 4: middle estimate off by 3.1-fold (0.49 log units), on the high side, outside the stated range (below it).
By their numbers in this assay, from the lowest: compounds 4 and 1 (each within the scatter of the next); then compound 3. At a limit, above all of these: compound 2.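

In this assay, the change from 4-methylpiperazin-1-yl to 4-ethylpiperazin-1-yl gives a 3.1-fold lower number from compound 3 to compound 4 (0.48 log units; beyond the scatter), so one added carbon at this place moves the read-out beyond the scatter towards stronger inhibition, and the whole-amine comparison then reads a 1.4-fold lower number from compound 1 to compound 4 (0.13 log units; within the scatter). The step from the 2-(2-hydroxyethyl)piperidin-1-yl compound to the ethyl compound reads an at least 6.2-fold lower number from compound 2 to compound 4 (0.79 log units; beyond the scatter). That step rests on a limit of the assay for compound 2, not on a number: the limit of > 100000 nM in this assay, at which 1 of the 4 values shown sits.

From the compounds shown here alone, whether the gain continues with a propyl or a butyl group on the piperazine nitrogen remains open, since only methyl and ethyl stand here. Also open, going by these compounds, is how a cyclopropyl group or a 2-hydroxyethyl group at the same place would read.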